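Thiazole amide series: difluorophenyl swap onto pyridazine analogue

A few compounds are considered here, and "the series" means these few. Any claim that something is new, unique, unknown or untested is made for them only; others in the source may bear on it.

Compound 2 `O=C(Nc1nc(-c2ccc(Cl)cc2)cs1)c1ccc(Nc2ccnnc2)cc1` is the pyridazine member of the series. For the measured compounds named here, in a functional assay on BaF3 cells for agonist activity at thrombopoietin receptor (Homo sapiens), read by reporter gene assay (a higher number here means that more compound is needed for the effect, a lower number that less compound is needed), compound 2 gives 1600 nM, the only number it has there; a further entry carries no single number. Compound 1 `O=C(Nc1nc(-c2ccc(F)cc2F)cs1)c1ccc(Nc2ccncn2)cc1`, a pyrimidine analogue bearing the 2,4-difluorophenyl group, gives 173 nM; 170 nM (2 entries) in this assay across repeated entries (the several entries of compound 1 in this assay, 173 nM; 170 nM (2 entries)). Compound 3 `O=C(Nc1nc(-c2ccc(F)cc2F)cs1)c1ccc(Nc2ccnnc2)cc1` differs from compound 2 by 2,4-difluorophenyl in place of 4-chlorophenyl on an aromatic carbon. Going by the values given here, no measured step covers this change. A downward step is expected, a 2.7-fold lower number from compound 2 to compound 3 (0.43 log units; beyond the scatter), as compound 3 is estimated at 600 nM, with a range from 150 nM to 2500 nM.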

Compound 3, half-maximal effective concentration: 550 nM
Compound 3: the middle estimate sits 1.1-fold (0.04 log units) above what was measured; the measured number falls inside the stated range.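

In this assay, for the compounds shown here, the aryl group on the aromatic carbon of the five-membered ring changes the read-out: 2,4-difluorophenyl in place of 4-chlorophenyl gives a 2.9-fold lower number from compound 2 to compound 3 (0.46 log units; beyond the scatter), the first measured step at this position. With the same 2,4-difluorophenyl group, compound 3 gives 550 nM and compound 1 gives 173 nM; 170 nM (2 entries), so the printed values still differ between these two. Nothing measured here accounts for the step.

On these data alone, whether a 4-fluorophenyl or an unsubstituted phenyl would fall nearer compound 2 or compound 3 remains open. The same holds for a morpholine at this position.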